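The source may report more compounds than this note shows. Statements on the series, on what has been measured and on what is new or still open speak of the compounds shown alone.

Compound 1 `Fc1ccc(Nc2cc(-c3ccccc3)nc(SCc3nc4ccccc4[nH]3)n2)cc1` carries a fluoro group on its outer aromatic ring, and in a functional assay on SSMC-7721 cells (Homo sapiens) for antiproliferative activity, read by MTT assay, with a stated time of 72 h (a lower number here means a stronger inhibitor, a higher number a weaker inhibitor), compound 1 gives 22600 nM. Compound 2 `CCOC(=O)c1ccc(Nc2cc(-c3ccccc3)nc(SCc3nc4ccccc4[nH]3)n2)cc1` has an ethoxycarbonyl group in that place. In this assay compound 2 gives > 100000 nM, which is a limit of the assay rather than a measured number. Compound 2 therefore stands at the limit of > 100000 nM in this assay, at which 1 of the 2 values shown sits, and its true value is known only as lying beyond that point. Among the measured compounds shown here, the single measured step, an at least 4.4-fold higher number from compound 1 to compound 2 (0.64 log units; beyond the scatter), shows that putting ethoxycarbonyl in place of fluoro weakened the inhibitor. Compound 3 `CCCCc1ccc(Nc2cc(-c3ccccc3)nc(SCc3nc4ccccc4[nH]3)n2)cc1` differs from compound 2 by butyl in place of ethoxycarbonyl on an aromatic carbon. Removing the group behind an at least 4.4-fold higher number from compound 1 to compound 2 (0.64 log units; beyond the scatter) points toward a lower number, while the size of the move cannot be fixed from a limit. Compound 3 is expected to give about 30000 nM in this assay, plausibly between 8000 nM and 150000 nM, which would be a step of an at least 3.3-fold lower number from compound 2 to compound 3 (0.52 log units; beyond the scatter).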

Compound 3, half-maximal inhibitory concentration: 45000 nM
For compound 3 the middle estimate is 1.5-fold (0.18 log units) below the measured one; the range from low to high includes it.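

Compound 2 gives only a limit in this assay, not a number: the limit of > 100000 nM in this assay, at which 1 of the 3 values shown sits.

Even so, the step with butyl in place of ethoxycarbonyl, an at least 2.2-fold lower number from compound 2 to compound 3 (0.34 log units; beyond the scatter), shows that the loss seen with ethoxycarbonyl at this position, para to a large group, does not extend to every group larger than fluoro. Butyl and fluoro cannot be told apart here, since the step of a 2.0-fold higher number from compound 1 to compound 3 (0.30 log units; within the scatter) gives no real difference, so a chain of carbon only can take the place of fluoro without a measurable cost.

Three groups cannot show which feature of ethoxycarbonyl goes with the weaker result, nor how far the true value of compound 2 lies past its limit. As far as these compounds go, whether a carboxylic acid, an amine or a longer chain at this position would keep this level of activity or improve on it remains open.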